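Diaryl urea pyrazole series: cytotoxicity limits in ovarian cells

The compounds below may be only part of what the source reports. "The series", "measured", "known", "first", "only" and "open" are said of these compounds alone.

Measured compounds in a functional assay on SK-OV-3 cells (Homo sapiens) for inhibition, read by sulforhodamine B assay, with a stated time of 48 h; a lower number here means that less compound is tolerated, a higher number that more compound is tolerated:
- compound 1 `O=C(Nc1cccc(-n2cc(-c3ccncc3)c(-c3ccc(Cl)c(O)c3)n2)c1)Nc1cccc(C(F)(F)F)c1`, a limit of the assay: > 32500 nM
- compound 2 `COc1cc(-c2nn(-c3cccc(NC(=O)Nc4cccc(C(F)(F)F)c4)c3)cc2-c2ccncc2)ccc1Cl`, a limit of the assay: > 50000 nM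
- compound 3 `COc1cc(-c2nn(-c3cccc(NC(=O)Nc4ccc(Cl)c(C(F)(F)F)c4)c3)cc2-c2ccncc2)ccc1Cl`, a limit of the assay: > 32500 nM

Among the measured compounds shown here, every value stands at a limit, two at the limit of > 32500 nM in this assay, at which 2 of the 3 values shown sit, and one at the limit of > 50000 nM in this assay, at which 1 of the 3 values shown sits, so no step is readable. From compound 2 to compound 1 the change is hydrogen in place of methyl on an oxygen on an aromatic ring, and in this assay it gives a step that the two limits leave unreadable from compound 2 to compound 1. Compound 2 and compound 3 differ in their cores by chloro in place of hydrogen on an aromatic carbon, with a step that the two limits leave unreadable from compound 2 to compound 3.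

Compound 4 `O=C(Nc1cccc(-n2cc(-c3ccncc3)c(-c3ccc(Cl)c(O)c3)n2)c1)Nc1ccc(Cl)c(C(F)(F)F)c1` is not yet measured; it differs from compound 3 by hydrogen in place of methyl on an oxygen on an aromatic ring, the same change as from compound 2 to compound 1, at a place described in the same words. Because compound 3 sits at the limit of > 32500 nM in this assay, at which 2 of the 3 values shown sit, and all three measured compounds reach only limits, compound 4 is expected to behave alike, so the estimated step is a step that the limit leaves unreadable from compound 3 to compound 4. In this assay compound 4 is estimated at 60000 nM, between 20000 nM and 200000 nM.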

Compound 4, concentration lethal to 50% of the cells: > 32500 nM
Compound 4: no number, only a limit (the forecaster's own chance of this, stated with the estimate: 85%); the middle value does not contradict the limit.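

Compound 4, like compound 1 and compound 3, stands only at a limit of the assay, so the steps from compound 3 and compound 1 to compound 4 cannot be read: the limit of > 32500 nM in this assay, at which 3 of the 4 values shown sit.

The compounds shown leave open whether methoxy to hydroxy or the added chloro changes the tolerated concentration at all.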